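Acyl chain variation on the ester of the shared core

The source may report more compounds than this note shows. Statements on the series, on what has been measured and on what is new or still open speak of the compounds shown alone.

Compound 2 `C/C=C/C=C/C(=O)O[C@H](CC=C(C)C)C1=CC(=O)c2c(O)ccc(O)c2C1=O` gives 130000 nM in an assay on HeLa cells for inhibition of DNA topoisomerase 1 (Homo sapiens); a higher number here means a weaker inhibitor, a lower number a stronger inhibitor; compound 1 `CC/C=C/CC(=O)O[C@H](CC=C(C)C)C1=CC(=O)c2c(O)ccc(O)c2C1=O` gives 153000 nM, and the step of a 1.2-fold lower number from compound 1 to compound 2 (0.07 log units; within the scatter) lies within the scatter, so the two stand together. Compound 3 `C=CCC/C=C/C(=O)O[C@H](CC=C(C)C)C1=CC(=O)c2c(O)ccc(O)c2C1=O` is not yet measured; it differs from compound 2 by but-3-en-1-yl in place of prop-1-en-1-yl on a double-bonded chain carbon bound to a double-bonded chain carbon. Among the measured compounds shown here, the only step that bears on it is the acyl-chain change from compound 1 to compound 2, which stayed within the scatter. No step beyond the scatter is therefore expected in this assay, either way. Compound 3 is estimated at 130000 nM, range 60000 nM to 280000 nM, a step of no change at the digits printed from compound 2 to compound 3 (within the scatter) that is expected to stay within the scatter.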

Compound 3, half-maximal inhibitory concentration: 126000 nM
The estimate for compound 3 lay 1.0-fold (0.01 log units) above the measured number; the range from low to high includes it.
By their numbers in this assay, from the lowest: compounds 3, 2 and 1 (each within the scatter of the next).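

Taking the acyl chain to hexa-1,5-dien-1-yl, with but-3-en-1-yl in place of prop-1-en-1-yl, gives a 1.0-fold lower number from compound 2 to compound 3 (0.01 log units; within the scatter) and so leaves this assay unmoved at this position. Set against the pent-2-en-1-yl-bearing chain, the same compound gives a 1.2-fold lower number from compound 1 to compound 3 (0.08 log units; within the scatter) and so all three chains stand together, whether the chain is the longer one or not. No measurement on hand accounts for this flat result.

Still open, on these data alone, is whether an amine or a carboxylic acid on the chain would take the number beyond the scatter. A much longer saturated chain or a phenyl ring in its place is equally untested among the compounds shown.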